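This account rests on a few compounds, and the source may have more. Where it says the series, first, only, none or still open, it means among the compounds named here.

Measured so far in a functional assay on DU-145 cells (Homo sapiens) for inhibition, read by trypan blue exclusion, with a stated time of 96 h; a lower number here means a stronger inhibitor of growth, a higher number a weaker inhibitor of growth:

- compound 1 `O=C(O)c1ccc(C(=O)/C(=C\c2ccc(Br)cc2)SCc2ccc(F)cc2)cc1`: > 100000 nM
- compound 2 `O=C(/C(=C\c1cc([N+](=O)[O-])ccc1F)S(=O)(=O)Cc1ccc(F)cc1)c1ccc(Br)cc1`: > 100000 nM

Compound 1 gives > 100000 nM, which is a limit of the assay and not a number. Compound 2 gives > 100000 nM, and this too is a limit. Compound 1 therefore stands with its only companion at the limit of > 100000 nM in this assay, at which 2 of the 2 values shown sit, so no measured number yet places either compound on the scale.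

Compound 3 `CN(C)c1ccc(/C=C(/SCc2ccc(F)cc2)C(=O)c2ccc(C(=O)O)cc2)cc1` keeps the core of compound 1 and changes one group: dimethylamino in place of bromo on an aromatic carbon. Dimethylamino takes the place of bromo on an aromatic carbon, para to a large group, so 4-bromophenyl becomes 4-(dimethylamino)phenyl.

Within the data shown here, no pair of measured compounds shows what such a change does in this assay. The expectation therefore rests on compound 1 at > 100000 nM. At most a modest move towards stronger growth inhibition is expected, and the result may well be another limit. The expected size of the change is an at least 2.0-fold lower number from compound 1 to compound 3 (0.30 log units; that floor lies within the scatter). For compound 3 the estimated value is 50000 nM, with an expected range from 8000 nM to 100000 nM.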

Compound 3, concentration for 50% growth inhibition: 10000 nM
Estimate against measurement, compound 3: 5.0-fold (0.70 log units) above; the measured number falls inside the stated range.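

Among these compounds, this result shows that the position para to a large group on the aromatic ring is not silent in this assay: replacing bromo with dimethylamino, so that 4-bromophenyl becomes 4-(dimethylamino)phenyl, gives an at least 10-fold lower number from compound 1 to compound 3 (1.00 log units; beyond the scatter) and moves the series onto the measurable scale for the first time. As far as these compounds go, compound 1 carries only a limit and not a number, so this step is a floor, and its true size stays unknown. Among the compounds shown here, compound 3 is the only one of the three compounds with a measured number, while the other two remain at the same limit: (the limit of > 100000 nM in this assay, at which 2 of the 3 values shown sit).

What a single change cannot tell is whether this gain belongs to dimethylamino in particular, or whether a smaller amine such as a primary amine, or a methoxy group, would do the same on that aromatic carbon. Also open, from the compounds shown here alone, is whether the same swap would give a step of similar size if the carboxylic acid of compound 3 gave way to an ester or an amide.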